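The compounds below may be only part of what the source reports. "The series", "measured", "known", "first", "only" and "open" are said of these compounds alone.

Measured compounds:
- compound 1, `CC/C(=C(/c1ccc(/C=C/C(=O)O)cc1)c1cc2ccccc2[nH]1)c1ccccc1C#N`: 9 nM
- compound 2, `CC/C(=C(/c1ccc(/C=C/C(=O)O)cc1)c1cc2ccccc2[nH]1)c1cccc(C)c1`: 140 nM

Both compounds were tested in a functional assay on MCF7 cells (Homo sapiens) for inhibition; on this read-out higher numbers stand for weaker inhibition and lower numbers for stronger inhibition. Going by the values given here, compound 2 has the higher of the two numbers; the only neighbour is compound 1, and the step of a 16-fold higher number from compound 1 to compound 2 (1.19 log units; beyond the scatter) came from swapping 2-cyanophenyl for 3-methylphenyl on the double-bonded chain carbon.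

Compound 3, `CC/C(=C(/c1ccc(/C=C/C(=O)O)cc1)c1cc2ccccc2[nH]1)c1cccc(C(F)(F)F)c1`, has not yet been measured. It differs from compound 2 by trifluoromethyl in place of methyl on an aromatic carbon.

Among the compounds with values here, no measured step covers this exchange. Within the data shown here, the one step known, from the nitrile-bearing ring to the methyl-bearing ring, concerns a different group at a different place, so it gives no direct guide. With nothing comparable to lean on, the expectation for compound 3 is a step of no change at the digits printed from compound 2 to compound 3 (within the scatter), that is, no change beyond the scatter. Compound 3 is therefore estimated at 140 nM, within 45 nM to 450 nM.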

Compound 3, half-maximal inhibitory concentration: 325 nM
For compound 3 the middle estimate is 2.3-fold (0.37 log units) below the measured one, within the range that was stated.
By their numbers in this assay, from the lowest: compound 1; then compound 2; then compound 3.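

In this assay the ring position that carries methyl in compound 2 proves sensitive to what sits on it, since trifluoromethyl there gives a 2.3-fold higher number from compound 2 to compound 3 (0.37 log units; beyond the scatter) and the change of a single small group is enough to move the number. The wider comparison gives a 36-fold higher number from compound 1 to compound 3 (1.56 log units; beyond the scatter) and shows that neither 3-methylphenyl nor 3-(trifluoromethyl)phenyl comes close to the 2-cyanophenyl of compound 1. Nothing available gives a measured reason for either step.

Still open, on these data alone, is whether a nitrile put in the place of the methyl would match compound 1, which would tell the effect of the group apart from the effect of its place on the ring. As far as these compounds go, it is equally open where an amine or a methoxy group at this place would fall relative to these three compounds.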